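This account rests on a few compounds, and the source may have more. Where it says the series, first, only, none or still open, it means among the compounds named here.

Compound 1 `CC[C@H](CCn1cncn1)c1ccccc1`: 99.8 ug/mL in an ADME assay on RD cells (Homo sapiens) for cytotoxicity, read by MTT assay, with a stated time of 3 days; on this read-out lower numbers stand for higher toxicity in this test and higher numbers for lower toxicity in this test
Compound 2 `CC[C@@H](CCn1cncn1)c1ccccc1`: 91.2 ug/mL

Compound 1 gives the highest of the two numbers, and compound 2 sits close to it, as the step of a 1.1-fold lower number from compound 1 to compound 2 (0.04 log units; within the scatter) shows; the two differ only in configuration (the fact that compounds 1 and 2 differ only in the configuration as drawn). Compound 3 `CC[C@H](CCn1cncn1)c1ccc(Cl)cc1` carries chloro in place of hydrogen on an aromatic carbon on compound 1. Going by the values given here, neither measured step involves such a change, so no step bears directly on it. Among the compounds with values here, the only comparison available lies within the scatter, which gives no expected direction. For compound 3 the estimate is 70 ug/mL, between 35 ug/mL and 140 ug/mL, meaning an expected step of a 1.4-fold lower number from compound 1 to compound 3 (0.15 log units; within the scatter).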

Compound 3, half-maximal cytotoxic concentration: 57 ug/mL
The estimate for compound 3 lay 1.2-fold (0.09 log units) above the measured number; low and high end bracket the measured number.
By their numbers in this assay, from the lowest: compounds 3, 2 and 1 (each within the scatter of the next).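

In this assay, the step of a 1.8-fold lower number from compound 1 to compound 3 (0.24 log units; within the scatter) comes with chloro in place of hydrogen on an aromatic carbon, para to a large group. This position on the ring therefore takes one chlorine atom with no shift that stands clear of the scatter, something the earlier pair, which differs only in configuration, could not show. Nothing on hand accounts for the size of this step. The compounds shown leave open how an amine, a carboxylic acid or a methoxy group would read at this position. They also leave open how chloro would read on compound 2.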